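The compounds below may be only part of what the source reports. "The series", "measured", "known", "first", "only" and "open" are said of these compounds alone.

Working notes on the series. In a functional assay on CHO-K1 cells for antagonist activity at transient receptor potential cation channel subfamily V member 1 (Homo sapiens), read by FLIPR (on this read-out higher numbers stand for weaker inhibition and lower numbers for stronger inhibition), compound 1 `Cc1ccc(Cl)cc1Nc1nc(C(F)(F)F)ccc1CNC(=O)C(C)c1ccc(NS(C)(=O)=O)c(F)c1` gives 14 nM. Compound 2 `CC(C(=O)NCc1ccc(C(F)(F)F)nc1NCc1cccnc1)c1ccc(NS(C)(=O)=O)c(F)c1`, in this assay, is reported as "not active" (no number reported), so compound 2 stands without a number. The step to compound 3 `CC(C(=O)NCc1ccc(C(F)(F)F)nc1N1CCC(=O)CC1)c1ccc(NS(C)(=O)=O)c(F)c1` is 4-oxopiperidin-1-yl in place of ((pyridin-3-yl)methyl)amino on an aromatic carbon. With no number for compound 2, the size of the step in this assay cannot be counted; compound 3 is expected to stay weak, with any change from compound 2 probably not beyond the scatter. Compound 3 is estimated at 3000 nM, expected between 400 nM and 20000 nM.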

Compound 3, inhibition constant: 91 nM
The estimate for compound 3 lay 33-fold (1.52 log units) above the measured number; the whole stated range lies above it.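

Compound 3 shows that this position, next to the ring nitrogen, can carry 4-oxopiperidin-1-yl, a non-aromatic ring with no hydrogen-bond donor, and keep a number in this assay, whereas compound 2 is "not active", so that step cannot be read as a size. Against the (5-chloro-2-methylphenyl)amino group, the change gives a 6.5-fold higher number from compound 1 to compound 3 (0.81 log units; beyond the scatter), so neither an aromatic ring nor an amino hydrogen at this position is required for a measurable number. No data here account for these differences. Open, going by these compounds, is whether the ring carbonyl contributes to the value of compound 3. A plain piperidin-1-yl or a morpholin-4-yl group at this position would test that.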